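The source may hold more compounds than are shown below. What is called first, only, known or untested is meant among the compounds shown, and "the series" means these compounds.

Compound 1 `O=C1NCCN1c1ccc(S(=O)(=O)Nc2ccc(C3CCCCC3)cc2)cc1`: > 1000 nM
Compound 2 `Cc1ccc(NS(=O)(=O)c2ccc(N3CCNC3=O)cc2)cc1`: 480 nM
Compound 3 `Cc1ccc(NS(=O)(=O)c2ccc(N3CCNC3=O)cc2)cc1C`: 230 nM

The three measured compounds share one core and differ only in the group carried on the sulfonamide nitrogen; all were tested in a functional assay on HT-29 cells (Homo sapiens) for antiproliferative activity, read by sulforhodamine B assay, with a stated time of 48 h; on this read-out lower numbers stand for stronger inhibition and higher numbers for weaker inhibition. For compound 1 the value > 1000 nM is a limit of the assay rather than a number. Among the measured compounds shown here, compound 2 gives 480 nM and compound 3 gives 230 nM, so compound 3 stands lowest of the two numbers measured so far. Two steps lead to it: an at least 2.0-fold lower number from compound 1 to compound 2 (0.31 log units; beyond the scatter), where a methyl took the place of cyclohexyl on an aromatic carbon, and a 2.1-fold lower number from compound 2 to compound 3 (0.32 log units; beyond the scatter), where a methyl took the place of hydrogen on an aromatic carbon.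

Compound 4 `O=C1NCCN1c1ccc(S(=O)(=O)Nc2ccc(Cl)cc2)cc1` is not yet measured in this assay. Its difference from compound 3 is 4-chlorophenyl in place of 3,4-dimethylphenyl on a sulfonamide nitrogen. For the measured compounds named here, only one measured step bears on this. Read in reverse, a 2.1-fold lower number from compound 2 to compound 3 (0.32 log units; beyond the scatter) suggests that losing one of the two methyls costs a modest rise in the number. Swapping the remaining methyl for chlorine has no measured counterpart among these compounds, so that part remains open. A modest rise is therefore expected, a 2.2-fold higher number from compound 3 to compound 4 (0.34 log units; beyond the scatter). Compound 4 is estimated at 500 nM, within a range from 200 nM to 1300 nM.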

Compound 4, half-maximal inhibitory concentration: 220 nM
Beside the measured number, compound 4's estimate is 2.3-fold (0.36 log units) above it; the measured number falls inside the stated range.
By their numbers in this assay, from the lowest: compounds 4 and 3 (each within the scatter of the next); then compound 2. At a limit, above all of these: compound 1.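

With a 1.0-fold lower number from compound 3 to compound 4 (0.02 log units; within the scatter) in this assay, 4-chlorophenyl and 3,4-dimethylphenyl on the sulfonamide nitrogen cannot be told apart, so this position accepts a ring with a single chloro as well as one with two methyls. The one-place comparison with a single methyl is more telling: chloro in place of methyl on an aromatic carbon gives a 2.2-fold lower number from compound 2 to compound 4 (0.34 log units; beyond the scatter) and that step lies beyond the scatter, which shows that a second methyl is not the only change among these compounds that lowers the number from that of compound 2. Swapping the cyclohexyl group for a chloro gives an at least 4.5-fold lower number from compound 1 to compound 4 (0.65 log units; beyond the scatter) and this comparison can only be read one way, as compound 1 holds a limit and not a number: the limit of > 1000 nM in this assay, at which 1 of the 4 values shown sits.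

As far as these compounds go, it remains open whether a second chloro on the 4-chlorophenyl ring would lower the number again, as the second methyl did in going to compound 3. The compounds shown also leave open how other groups on that ring, such as a methoxy, an amine or a carboxylic acid, would compare with chloro and methyl.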